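Oxalamide in place of malonamide on the shared core

The source may hold more compounds than are shown below. What is called first, only, known or untested is meant among the compounds shown, and "the series" means these compounds.

Compound 1 `Cc1cc2cc(NC(=O)C(=O)O)ccc2n1Cc1ccc(O)c(C(C)C)c1`: 1500 nM
Compound 2 `Cc1cc2c(NC(=O)CC(=O)O)cccc2n1Cc1ccc(O)c(C(C)C)c1`: 230 nM

Of the compounds shown here, two have been measured in an assay on isolated protein for displacement of a labelled ligand from thyroid hormone receptor beta (Homo sapiens), with a stated time of 3 h; on this read-out lower numbers stand for stronger inhibition and higher numbers for weaker inhibition. Compound 1 gives 1500 nM and compound 2 gives 230 nM; compound 2 thus holds the lower of the two numbers, and the gap between them lies beyond the scatter. Among the measured compounds shown here, the two structures differ in more than one place, so no single step connects them.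

Compound 3 `Cc1cc2c(NC(=O)C(=O)O)cccc2n1Cc1ccc(O)c(C(C)C)c1` keeps the core of compound 2 and changes only the acid side chain: carboxy in place of carboxymethyl on a carbonyl carbon. For the measured compounds named here, no measured pair shows this change on its own, so its size cannot be read from the data. The step from compound 2 to compound 3 in this assay is expected to be small, a 1.7-fold higher number from compound 2 to compound 3 (0.24 log units; within the scatter), with a modest loss of affinity considered somewhat more likely than a gain. Compound 3 is therefore estimated at 400 nM, within a range from 100 nM to 1600 nM.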

Compound 3, half-maximal inhibitory concentration: 40 nM
Compound 3: middle estimate off by 10-fold (1.00 log units), on the high side, outside the stated range (below it).
By their numbers in this assay, from the lowest: compound 3; then compound 2; then compound 1.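

In this assay, carboxy in place of carboxymethyl on a carbonyl carbon gives a 5.8-fold lower number from compound 2 to compound 3 (0.76 log units; beyond the scatter), so at this position the acid side chain is sensitive to this single change. Among the compounds shown here, this is the first step that isolates one change, and it favours the carboxy form on this core. Compound 1 carries the same (carboxycarbonyl)amino group elsewhere on the shared core and gives 1500 nM, while compound 3 gives 40 nM, so the printed values also differ widely with where that group sits.

No measured evidence here accounts for the size of this step. The compounds shown leave open how an amine, a tetrazole or a chain longer than carboxymethyl would read at this position, and whether the step from carboxymethyl to carboxy would hold on another core.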